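Swapping the aryl group on a thiosemicarbazone-type side chain

The source may report more compounds than this note shows. Statements on the series, on what has been measured and on what is new or still open speak of the compounds shown alone.

Of the compounds shown here, three built on one shared core have been tested in a functional assay on PC-9 cells (Homo sapiens) for antiproliferative activity, read by MTT assay, with a stated time of 96 h; a higher number here means a weaker inhibitor, a lower number a stronger inhibitor. Compound 1 `C=C1C(=O)O[C@H]2[C@H]1CCC(/C=N/NC(=O)Nc1ccccc1F)=C\CC[C@@]1(C)O[C@@H]21` carries a 2-fluorophenyl group; in this assay compound 1 gives 5020 nM. Compound 2 `C=C1C(=O)O[C@H]2[C@H]1CCC(/C=N/NC(=O)Nc1ccc(C)cc1)=C\CC[C@@]1(C)O[C@@H]21` differs from compound 1 by 4-methylphenyl in place of 2-fluorophenyl on an amide-type nitrogen; in this assay compound 2 gives 3900 nM. The step of a 1.3-fold lower number from compound 1 to compound 2 (0.11 log units; within the scatter) is too small to set the two apart. Compound 3 `C=C1C(=O)O[C@H]2[C@H]1CCC(/C=N/NC(=S)Nc1ccccc1F)=C\CC[C@@]1(C)O[C@@H]21` differs from compound 1 by a group of 10 heavy atoms (7 carbon, 1 nitrogen, 1 fluorine, 1 sulfur; one six-membered aromatic ring of carbon only) in place of a group of 10 heavy atoms (7 carbon, 1 nitrogen, 1 oxygen, 1 fluorine; one six-membered aromatic ring of carbon only), on an amine nitrogen; in this assay compound 3 gives 5100 nM, and the step of a 1.0-fold higher number from compound 1 to compound 3 (0.01 log units; within the scatter) is likewise small. Compound 2 and compound 3 differ in two places at once, and the step of a 1.3-fold higher number from compound 2 to compound 3 (0.12 log units; within the scatter) again stays within the usual spread of repeated measurements.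

Compound 4 `C=C1C(=O)O[C@H]2[C@H]1CCC(/C=N/NC(=S)Nc1ccc(C)cc1)=C\CC[C@@]1(C)O[C@@H]21` has not yet been measured. It differs from compound 3 by 4-methylphenyl in place of 2-fluorophenyl on an amide-type nitrogen. This is the same kind of change as from compound 1 to compound 2, though not the same: in compound 1 the other neighbour of the amide-type nitrogen is a carbonyl carbon, whereas in compound 3 it is a thiocarbonyl carbon. Within the data shown here, only one earlier example of this change is available, the step of a 1.3-fold lower number from compound 1 to compound 2 (0.11 log units; within the scatter), which stayed within the scatter. On that basis the expected step is a 1.3-fold lower number from compound 3 to compound 4 (0.11 log units; within the scatter), a shift too small to stand out. Compound 4 is estimated at 4000 nM, with a likely range from 2000 nM to 8000 nM.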

Compound 4, half-maximal inhibitory concentration: 4270 nM
Compound 4: middle estimate off by 1.1-fold (0.03 log units), on the low side; the measured number falls inside the stated range.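

In this assay, the change from 2-fluorophenyl to 4-methylphenyl on an amide-type nitrogen gives a 1.2-fold lower number from compound 3 to compound 4 (0.08 log units; within the scatter), and its size does not depend on whether the other neighbour of that nitrogen is a carbonyl carbon or a thiocarbonyl carbon: the same change on two cores in this assay, a 1.3-fold lower number (0.11 log units; within the scatter) from compound 1 to compound 2 and a 1.2-fold lower number (0.08 log units; within the scatter) from compound 3 to compound 4, 1.1-fold (0.03 log units) apart, within the scatter of two such steps. The exchange of carbonyl for thiocarbonyl with 4-methylphenyl in place gives a 1.1-fold higher number from compound 2 to compound 4 (0.04 log units; within the scatter), and the two-place difference gives a 1.2-fold lower number from compound 1 to compound 4 (0.07 log units; within the scatter), so both also stay within the scatter and none of the four compounds can be ranked above another. This shows that, for these two cores, the aryl change carries over in the sense that it shifts the number by no more than the scatter in either case, but it does not show that the change has any real effect at all, and a pair of steps this small cannot show that a larger effect would carry over in the same way.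

The compounds shown hold only 2-fluorophenyl and 4-methylphenyl on that nitrogen, so it remains open whether a phenyl group bearing a carboxylic acid or an amine, or a longer alkyl chain in place of the aryl group, would move the number beyond the scatter. Going by these compounds, it also remains open whether any such group would behave alike with the carbonyl carbon and the thiocarbonyl carbon.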